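Benzylsulfanyl in place of cyclopropylamino on a shared core

This account rests on a few compounds, and the source may have more. Where it says the series, first, only, none or still open, it means among the compounds named here.

Compound 2 `Nc1nc(NC2CC2)c2ncn(/C=C3/CC3(CO)CO)c2n1` is one of three compounds on a shared core whose tolerance was read in an ADME assay on MOLT-3 cells (Homo sapiens) for cytotoxicity, with a stated time of 7 days; a lower number here means that less compound is tolerated, a higher number that more compound is tolerated. Compound 2 gives > 20000 nM, a limit of the assay rather than a number. Compound 1 `CNc1nc(N)nc2c1ncn2/C=C1/CC1(CO)CO` gives > 20000 nM, also a limit. Compound 3 `CCCCNc1nc(N)nc2c1ncn2/C=C1/CC1(CO)CO` gives > 20000 nM, again a limit. The three steps among them, a step that the two limits leave unreadable from compound 1 to compound 2, a step that the two limits leave unreadable from compound 1 to compound 3 and a step that the two limits leave unreadable from compound 2 to compound 3, therefore show no readable size, because of the limit of > 20000 nM in this assay, at which 3 of the 3 values shown sit.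

Compound 4 `Nc1nc(SCc2ccccc2)c2ncn(/C=C3/CC3(CO)CO)c2n1` differs from compound 2 by benzylsulfanyl in place of cyclopropylamino on an aromatic carbon. Within the data shown here, none of the measured steps touches a sulfur-linked group, and none of them has a readable size, so no measured step gives a direction for this change. Among the measured compounds shown here, the shared pattern of limits across compounds 1, 2 and 3 is the only guide, and compound 4 is expected to stay close to it, with a step of about a number no higher from compound 2 to compound 4 (the limit leaves the size open). Compound 4 is thus estimated at 20000 nM, within a range from 5000 nM to 60000 nM, with a fair chance that only a limit is reported.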

Compound 4, half-maximal cytotoxic concentration: > 20000 nM
Compound 4 ended at the assay's limit; the forecaster's own chance of this, stated with the estimate: 65%; the middle value lies on the limit itself.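

No step from compound 1, compound 2 or compound 3 to compound 4 can be read, because each of these compounds ends on a limit and not a number: the limit of > 20000 nM in this assay, at which 4 of the 4 values shown sit.

The compounds shown leave open whether benzylsulfanyl and the amino groups differ in tolerance at all.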